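A few compounds are considered here, and "the series" means these few. Any claim that something is new, unique, unknown or untested is made for them only; others in the source may bear on it.

Measured compounds in a functional assay on BJAB cells (Homo sapiens) for antiproliferative activity, with a stated time of 4 days; on this read-out lower numbers stand for an effect already at smaller amounts and higher numbers for an effect only at larger amounts of compound:
- compound 1 `Cc1nn(-c2nc(-c3ccc(Cl)c(Cl)c3)c(SC(C)C)s2)c(C(=O)O)c1-c1cccnc1`: 12000 nM
- compound 2 `Cc1nn(-c2nc(-c3ccc(Cl)c(Cl)c3)c(SC(C)C)s2)c(C(=O)O)c1-c1ccccc1C(F)(F)F`: 5200 nM
- compound 3 `CC(=O)Nc1ccc(-c2c(C)nn(-c3nc(-c4ccc(Cl)c(Cl)c4)c(SC(C)C)s3)c2C(=O)O)cc1`: 139000 nM

Compound 3 carries the highest number of the three. Its nearest neighbour is compound 1, a step of a 12-fold higher number from compound 1 to compound 3 (1.06 log units; beyond the scatter); its furthest is compound 2, a step of a 27-fold higher number from compound 2 to compound 3 (1.43 log units; beyond the scatter). Within this set the 4-acetamidophenyl arm thus sits far above either of the other two aryl groups, while compound 1 and compound 2 differ from each other only by a 2.3-fold lower number from compound 1 to compound 2 (0.36 log units; beyond the scatter).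

Compound 4 `CCOc1ncccc1-c1c(C)nn(-c2nc(-c3ccc(Cl)c(Cl)c3)c(SC(C)C)s2)c1C(=O)O` has not yet been measured. The change from compound 3 is 2-ethoxypyridin-3-yl in place of 4-acetamidophenyl on an aromatic carbon. The two measured steps that bear on it are those into compound 3, both large and both pointing to the 4-acetamidophenyl group as the cause of the high number; no step in the set directly covers a 2-ethoxypyridin-3-yl group, so the closest analogue is the pyridin-3-yl of compound 1. Removing the 4-acetamidophenyl is therefore expected to bring the number back down by a large step, roughly the reverse of a 12-fold higher number from compound 1 to compound 3 (1.06 log units; beyond the scatter), with compound 1 and compound 2 marking the likely range.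

For compound 4 the expected value is 8000 nM, within 2500 nM to 25000 nM. The expected step is a 17-fold lower number from compound 3 to compound 4 (1.24 log units; beyond the scatter).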

Compound 4, half-maximal effective concentration: 11000 nM
Compound 4: middle estimate off by 1.4-fold (0.14 log units), on the low side; the range from low to high includes it.
By their numbers in this assay, from the lowest: compound 2; then compounds 4 and 1 (each within the scatter of the next); then compound 3.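

In this assay, ethoxy in place of hydrogen on the pyridin-3-yl group gives a 1.1-fold lower number from compound 1 to compound 4 (0.04 log units; within the scatter) and stays within the scatter, so this position accepts the 2-ethoxypyridin-3-yl group without a measurable change from the unsubstituted pyridin-3-yl. The same group in place of 4-acetamidophenyl gives a 13-fold lower number from compound 3 to compound 4 (1.10 log units; beyond the scatter) as a large step, while in place of 2-(trifluoromethyl)phenyl it gives a 2.1-fold higher number from compound 2 to compound 4 (0.33 log units; beyond the scatter) as a modest one, which leaves compound 3 alone at the high end among the four aryl groups and shows that a substituted aryl group at this carbon does not by itself raise the number. The data offer no measured explanation for the gap between compound 3 and the other three compounds.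

Still open, on these data alone, is whether the high number of compound 3 belongs to the acetamido group itself or to any group at the 4-position of the phenyl ring, which a 4-aminophenyl or 4-methoxyphenyl group, or a 2-acetamidophenyl group, would test. Also open, as far as these compounds go, is how far the chain on the pyridin-3-yl group can grow, for example from ethoxy to butoxy or benzyloxy, before the number moves beyond the scatter.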